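The compounds below may be only part of what the source reports. "The series", "measured", "known", "first", "only" and "open" are said of these compounds alone.

Compound 3 `O=C(COc1ccc2cc(/C=C3/SC(=O)NC3=O)ccc2c1)Nc1ccc([N+](=O)[O-])cc1` stands at the lower end of the two numbers that have been measured in an assay on isolated protein for inhibition of histone deacetylase 8 (Homo sapiens), with a stated time of 1 h; a lower number here means a stronger inhibitor, a higher number a weaker inhibitor; compound 3 gives 4000 nM. Its nearest neighbour is compound 1 `COc1cccc(NC(=O)COc2ccc3cc(/C=C4/SC(=O)NC4=O)ccc3c2)c1`, which in this assay gives 7600 nM, and the step of a 1.9-fold lower number from compound 1 to compound 3 (0.28 log units; within the scatter) lies within the scatter, so the two cannot be put in order. Compound 2 `O=C(COc1ccc2cc(/C=C3/SC(=O)NC3=O)ccc2c1)Nc1ccc(F)cc1F` returns only a limit in this assay, namely > 50000 nM. The step of an at least 6.5-fold higher number from compound 1 to compound 2 (0.81 log units; beyond the scatter) and the step of an at least 12-fold lower number from compound 2 to compound 3 (1.09 log units; beyond the scatter) both rest on (the limit of > 50000 nM in this assay, at which 1 of the 3 values shown sits), so their exact size is open, but their direction is clear.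

Compound 4 `O=C(COc1ccc2cc(/C=C3/SC(=O)NC3=O)ccc2c1)Nc1c(F)cc(F)cc1Br` differs from compound 3 in one place: 2-bromo-4,6-difluorophenyl in place of 4-nitrophenyl on an amide-type nitrogen. Among the compounds with values here, only the step from compound 2 to compound 3 bears directly on this change, and it ran in the opposite direction, from a fluorinated phenyl to the nitrophenyl, with a large fall. Returning to a halogenated phenyl, now carrying bromine as well, is therefore expected to raise the number in this assay for compound 4, and the step of a 6.3-fold higher number from compound 3 to compound 4 (0.80 log units; beyond the scatter) is the estimate. For compound 4 the expected value is 25000 nM, with a range from 6000 nM to 100000 nM, and a real chance that only a limit is reported.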

Compound 4, half-maximal inhibitory concentration: > 50000 nM
Compound 4 was reported as a limit (the forecaster's own chance of this, stated with the estimate: 40%); middle value at least 2.0-fold (0.30 log units) away from the limit.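

On the amide-type nitrogen, 2-bromo-4,6-difluorophenyl gives an at least 12-fold higher number from compound 3 to compound 4 (1.09 log units; beyond the scatter) in this assay, and an at least 6.5-fold higher number from compound 1 to compound 4 (0.81 log units; beyond the scatter). Among the compounds shown, the 2,4-difluorophenyl of compound 2 is thus no longer a lone case: both compounds with halogens on this phenyl ring, compound 2 and compound 4, return only a limit, while the 4-nitrophenyl and 3-methoxyphenyl compounds return readable numbers, and no compound shown goes against this. As far as these compounds go, the step from compound 2 to compound 4, bromo in place of hydrogen on an aromatic carbon, cannot be read, since both values are limits, so whether the added bromine changes anything stays unknown: the limit of > 50000 nM in this assay, at which 2 of the 4 values shown sit.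

The compounds shown leave open whether a single halogen, such as one chlorine or one fluorine on the phenyl ring, would also end at the limit or would give a readable number. They also leave open how a 4-aminophenyl or a 4-carboxyphenyl group in place of 4-nitrophenyl on the amide-type nitrogen would read in this assay.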